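From a Cyclopropane Acid to a Dimethylamide Chain

The compounds below may be only part of what the source reports. "The series", "measured", "known", "first", "only" and "open" are said of these compounds alone.

Compound 1 `O=C(O)CCCc1ccc(NCc2cccc(Oc3ccccc3)c2)cc1`, compound 2 `O=C(O)[C@H]1C[C@@H]1c1ccc(NCc2cccc(Oc3ccccc3)c2)cc1` and compound 3 `O=C(O)[C@@H]1C[C@H]1c1ccc(NCc2cccc(Oc3ccccc3)c2)cc1` share one core and differ only in the acid-bearing group on an aromatic carbon. In a functional assay on CHO cells for agonist activity at Free fatty acid receptor 1 (Homo sapiens), read by a luciferase reporter (on this read-out lower numbers stand for smaller maximal responses and higher numbers for larger maximal responses), compound 1 gives 59%, compound 2 gives 88%; 72% (2 entries), and compound 3 gives 64%. Within the data shown here, the one step between single numbers, a number 5 percentage points higher from compound 1 to compound 3 (within the scatter), leaves compound 3 and compound 1 within the scatter of each other; compound 2, which differs from compound 3 only in the configuration as drawn (the fact that compounds 2 and 3 differ only in the configuration as drawn), shows two entries the several entries of compound 2 in this assay, 88%; 72% (2 entries) that spread to either side of those values. Compound 4 `CN(C)C(=O)CCc1ccc(NCc2cccc(Oc3ccccc3)c2)cc1` carries 2-(dimethylcarbamoyl)ethyl in place of 2-carboxycyclopropyl on an aromatic carbon. Among the measured compounds shown here, no measured step bears on this exchange: every compound measured so far kept the carboxylic acid, and the only step known, between two acids, stayed within the scatter. The departing group carries one hydrogen-bond donor, the entering group none. The expected step of a number 34 percentage points lower from compound 3 to compound 4 (beyond the scatter) is downward and beyond the scatter, with wide uncertainty. For compound 4 the estimate in this assay is 30%, in a range from 5% to 65%.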

Compound 4, largest response reached (reported as percent of maximum), in percent of the reference or control that the assay uses: 50%
Beside the measured number, compound 4's estimate is 20 percentage points below it, within the range that was stated.
By their numbers in this assay, from the lowest: compounds 4, 1 and 3 (each within the scatter of the next, the first and the last beyond it).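

Among these compounds, compound 4 is the first compound here without a carboxylic acid, and at this position, para to a large group, it still gives a measurable maximal response in this assay. Exchanging 2-carboxycyclopropyl for 2-(dimethylcarbamoyl)ethyl costs only a number 14 percentage points lower from compound 3 to compound 4 (beyond the scatter), while the comparison with the 3-carboxypropyl chain gives a number 9 percentage points lower from compound 1 to compound 4 (within the scatter), so on this read-out the amide chain stays close to both acids. Nothing measured here accounts for either step.

The step from the cyclopropane acid also removes the ring and both defined stereocentres, and these compounds do not separate those changes from the loss of the acid. They also leave open how a primary amide or a longer chain ending in dimethylcarbamoyl would read at this position.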